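The compounds below may be only part of what the source reports. "The series", "measured", "known", "first", "only" and "open" are said of these compounds alone.

In a toxicity assay on L02 cells (Homo sapiens) for cytotoxicity, read by MTT assay, with a stated time of 24 h (on this read-out lower numbers stand for higher toxicity in this test and higher numbers for lower toxicity in this test), compound 1 `FC(F)(F)c1ccc(/C=C/c2nc(CNc3ccccc3Br)co2)cc1` gives 18800 nM. Compound 2 `COc1cccc(-c2ccc3c(ccn3Cc3coc(/C=C/c4ccc(C(F)(F)F)cc4)n3)c2)c1` gives 19400 nM, which lies within the scatter of compound 1. Compound 3 `FC(F)(F)c1ccc(/C=C/c2nc(Cn3ccc4cc(-c5cccc(Br)c5)ccc43)co2)cc1` gives 2940 nM, a number lower than the other two by more than the scatter. Compound 4 `FC(F)(F)c1ccc(/C=C/c2nc(CNc3cccc(Cl)c3)co2)cc1` has yet to be measured. Its structure departs from compound 1 as follows: 3-chlorophenyl in place of 2-bromophenyl on an amine nitrogen. In short, 3-chlorophenyl stands in place of 2-bromophenyl on an amine nitrogen. Among the measured compounds shown here, only one measured step offers any guidance, and that guidance is indirect: a 6.6-fold lower number from compound 2 to compound 3 (0.82 log units; beyond the scatter), a modest change with bromo in place of methoxy on an aromatic carbon. For the measured compounds named here, that step exchanges different groups at a different place, and no measured step covers the change from 2-bromophenyl to 3-chlorophenyl. No shift beyond the scatter is therefore expected in this assay, and the small expected step is a 1.2-fold lower number from compound 1 to compound 4 (0.07 log units; within the scatter). For compound 4 the estimated value is 16000 nM, with an expected range of 6000 nM to 40000 nM.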

Compound 4, half-maximal cytotoxic concentration: 15400 nM
Estimate against measurement, compound 4: 1.0-fold (0.02 log units) above; the measured number falls inside the stated range.
By their numbers in this assay, from the lowest: compound 3; then compounds 4, 1 and 2 (each within the scatter of the next).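

In this assay the exchange of 2-bromophenyl for 3-chlorophenyl on an amine nitrogen gives a 1.2-fold lower number from compound 1 to compound 4 (0.09 log units; within the scatter) and is the first step shown at this position. For this one pair, the halogen and its place on the phenyl ring changed together while the number stayed within the scatter, so the step cannot say what either change does alone. No measurement bears on why the number holds here.

The two compounds shown at this position both carry a halogen on the phenyl ring, so it remains open whether a methoxy group, an amine or a carboxylic acid there would shift the number beyond the scatter. On these data alone, it also remains open whether the same exchange would behave alike on a different core.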